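Triazole series: swapping allyl for trifluoromethylbenzyl

This account rests on a few compounds, and the source may have more. Where it says the series, first, only, none or still open, it means among the compounds named here.

Compound 3 `C=CCn1cc(COc2cc(O)c3c(c2)O[C@H](c2ccc(OC)c(O)c2)CC3=O)nn1` gives 13800 nM in a functional assay on RAW264.7 cells (Mus musculus) for inhibition, read by Griess assay, with stated times of 2 h and 24 h (on this read-out higher numbers stand for weaker inhibition and lower numbers for stronger inhibition), the second highest of the three numbers. Compound 1 `C#CCOc1cc(O)c2c(c1)O[C@H](c1ccc(OC)c(O)c1)CC2=O` gives 20900 nM, and the step of a 1.5-fold lower number from compound 1 to compound 3 (0.18 log units; within the scatter) lies within the scatter. Going by the values given here, compound 2 `CCCn1cc(COc2cc(O)c3c(c2)O[C@H](c2ccc(OC)c(O)c2)C/C3=N\O)nn1` gives 2340 nM, a lower number than compound 3, but it differs from compound 3 in two places, so no single step connects them. Compound 4 `COc1ccc([C@@H]2CC(=O)c3c(O)cc(OCc4cn(Cc5cccc(C(F)(F)F)c5)nn4)cc3O2)cc1O` carries 3-(trifluoromethyl)phenyl in place of vinyl on a saturated chain carbon bound to an aromatic nitrogen. Among the compounds with values here, no measured step touches this position on the triazole nitrogen, so no direction is indicated; the expected step of a 1.5-fold lower number from compound 3 to compound 4 (0.19 log units; within the scatter) is small. Compound 4 is therefore estimated at 9000 nM, within 2500 nM to 30000 nM.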

Compound 4, half-maximal inhibitory concentration: 19900 nM
Compound 4: the middle estimate sits 2.2-fold (0.34 log units) below what was measured; low and high end bracket the measured number.
By their numbers in this assay, from the lowest: compound 2; then compounds 3, 4 and 1 (each within the scatter of the next).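

Swapping allyl for 3-(trifluoromethyl)benzyl is the first measured change at this position, on a saturated chain carbon bound to an aromatic nitrogen. In this assay, the step is a 1.4-fold higher number from compound 3 to compound 4 (0.16 log units; within the scatter), so a group of 10 heavy atoms with an aromatic ring, replacing one of 2, leaves the number unchanged within the scatter. Nothing available gives a reason for this result. Still open, as far as these compounds go, is how an amine or a carboxylic acid would read here. Plain benzyl, without the trifluoromethyl, is also open.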